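Swapping the aryl group: compound 2 to compound 3

The source may report more compounds than this note shows. Statements on the series, on what has been measured and on what is new or still open speak of the compounds shown alone.

Measured in a functional assay on MGC-803 cells (Homo sapiens) for antiproliferative activity, read by CellTiter-Glo, with a stated time of 72 h; on this read-out higher numbers stand for weaker inhibition and lower numbers for stronger inhibition:
compound 1 `O=C(NO)c1ccc(/C=C/c2ccnc(-c3cccc(CO)c3)c2)cc1`: 1740 nM
compound 2 `O=C(NO)c1ccc(/C=C/c2ccnc(-c3cccnc3)c2)cc1`: 4550 nM

Of the two, compound 2 has the higher number, 4550 nM, so it shows the weaker inhibition. Compound 3 `O=C(NO)c1ccc(/C=C/c2ccnc(-c3ccc(F)cc3)c2)cc1` carries 4-fluorophenyl in place of pyridin-3-yl on an aromatic carbon, next to the ring nitrogen: 4-fluorophenyl in place of pyridin-3-yl on an aromatic carbon. Going by the values given here, only one measured step bears on this place: a 2.6-fold higher number from compound 1 to compound 2 (0.42 log units; beyond the scatter), where pyridin-3-yl replaced 3-(hydroxymethyl)phenyl. As far as these compounds go, that single modest step suggests a similar move back in this assay, towards a lower number, though 4-fluorophenyl itself is untested. The expected step is a 2.1-fold lower number from compound 2 to compound 3 (0.32 log units; beyond the scatter). For compound 3 the estimated value is 2200 nM, with an expected range of 850 nM to 5500 nM.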

Compound 3, half-maximal inhibitory concentration: > 10000 nM
Compound 3: no number, only a limit (the forecaster's own chance of this, stated with the estimate: 3%); middle value at least 4.5-fold (0.65 log units) from the limit.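

In this assay, compound 3 gives only a limit, not a number: the limit of > 10000 nM in this assay, at which 1 of the 3 values shown sits.

Replacing pyridin-3-yl with 4-fluorophenyl gives an at least 2.1-fold higher number from compound 2 to compound 3 (0.34 log units; beyond the scatter), and replacing 3-(hydroxymethyl)phenyl with it gives an at least 5.7-fold higher number from compound 1 to compound 3 (0.75 log units; beyond the scatter). Going by these compounds alone, this position therefore separates six-membered aromatic rings more sharply than the single earlier step showed.

As far as these compounds go, the full size of both steps stays open, as does whether the fluorine or the missing ring nitrogen accounts for the change. From the compounds shown here alone, how an unsubstituted phenyl or an aminophenyl would behave at this position also remains open.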